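One stereocentre changed at an assay limit

A few compounds are considered here, and "the series" means these few. Any claim that something is new, unique, unknown or untested is made for them only; others in the source may bear on it.

Compound 1 `C/C1=C/[C@]23O[C@]2(CC(C)(C)C3=O)[C@H](C)CC[C@@H]1O` | > 10 ug/mL
Compound 2 `C/C1=C/C2=CC(C)(C)C[C@@]2(OO)[C@H](C)CC[C@@H]1O` | > 10 ug/mL

Both entries come from a functional assay on HepG2 cells (Homo sapiens) for cytotoxicity, read by MTT assay (a higher number here means a weaker inhibitor, a lower number a stronger inhibitor), and match one shared result, (the limit of > 10 ug/mL in this assay, at which 2 of the 2 values shown sit), so neither is a number. In this assay compound 2 gives > 10 ug/mL as a limit. Compound 3 `C/C1=C/C2=CC(C)(C)C[C@]2(OO)[C@H](C)CC[C@@H]1O` differs from compound 2 in one way: the two compounds have the same atoms and bonds and differ only in configuration as drawn: 1 of 4 stereo elements differ; a stereocentre at a saturated ring carbon is drawn R in compound 2 and S in compound 3. Within the data shown here, no measured pair shows the size of such a change. The expected step that the limit leaves unreadable from compound 2 to compound 3 stays within the scatter and has no expected direction. The estimate for compound 3 is 14 ug/mL with an expected range from 6 ug/mL to 40 ug/mL in this assay, and another limit is likely.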

Compound 3, half-maximal inhibitory concentration: > 10 ug/mL
Compound 3: only a limit was reported (the forecaster's own chance of this, stated with the estimate: 75%); the middle value is on the limit's open side.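

In this assay, among these compounds, compound 2 and compound 3 both give only a limit, and no step between them can be read. On these data alone, whether the changed stereocentre affects cytotoxicity at all, and by how much, stays open.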